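This account rests on a few compounds, and the source may have more. Where it says the series, first, only, none or still open, it means among the compounds named here.

Measured so far:
compound 1, `Nc1nc(O)c2c(n1)n(C1OC(CO)[C@@H](O)[C@H]1O)c(=O)n2CC(O)CO`: 45 uM in a functional assay (B cells) with Mus musculus as the target; a lower number here means that less compound is needed, a higher number that more compound is needed for the effect
compound 2, `C=CCn1c(=S)n(C2OC(CO)[C@@H](O)C(O)[C@H]2O)c2nc(N)nc(O)c21`: 1 uM in this assay

Compound 1 holds the highest number of the two; compound 2 lies a wide gap below it, beyond the usual scatter, but the two differ at several places, so nothing about one change can be read from that pair.

Compound 3, `CCCCn1c(=O)n(C2OC(CO)[C@@H](O)[C@H]2O)c2nc(N)nc(O)c21`, differs from compound 1 at one place: propyl in place of 1,2-dihydroxyethyl on a saturated chain carbon bound to an aromatic nitrogen. Within the data shown here, no measured pair isolates this change. A moderate fall in the number, beyond the scatter, is expected. Compound 3 is expected to give 10 uM, between 2 uM and 45 uM. The expected step is a 4.5-fold lower number from compound 1 to compound 3 (0.65 log units; beyond the scatter).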

Compound 3, concentration for half-maximal effect: 11 uM
Estimate against measurement, compound 3: 1.1-fold (0.04 log units) below; low and high end bracket the measured number.
By their numbers in this assay, from the lowest: compound 2; then compound 3; then compound 1.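

In this assay, among these compounds, propyl in place of 1,2-dihydroxyethyl on a saturated chain carbon bound to an aromatic nitrogen gives a 4.1-fold lower number from compound 1 to compound 3 (0.61 log units; beyond the scatter), the first single change that can be read at this position. The number falls even though the entering group has no hydrogen-bond donors or acceptors, so the hydroxyl groups of compound 1 are not needed to reach this level of activity. Nothing measured here explains the step.

As far as these compounds go, whether an amine, a carboxylic acid or a longer chain such as hexyl at this position would shift the number further remains open. Compound 2 differs from the others at several places, so its steps to them cannot be read.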